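This account rests on a few compounds, and the source may have more. Where it says the series, first, only, none or still open, it means among the compounds named here.

The series shares one amide-linked acid portion; compound 1 `C[C@H](NC(=O)c1nnn(Cc2ccc(F)cc2)c1C(F)(F)F)c1ccc(C(=O)O)cc1`, compound 2 `C[C@H](NC(=O)c1nnn(Cc2cccc(C(F)(F)F)c2)c1C(F)(F)F)c1ccc(C(=O)O)cc1` and compound 3 `C[C@H](NC(=O)c1cn(Cc2ccc(C(F)(F)F)cc2)nn1)c1ccc(C(=O)O)cc1` differ in the benzyl group and in the substituent on the core. In a functional assay on CHO cells for antagonist activity at prostaglandin E2 receptor EP4 subtype (Homo sapiens), read by calcium flux, with a stated time of 15 min (a lower number here means a stronger inhibitor, a higher number a weaker inhibitor), compound 1 gives > 10000 nM, which is a limit of the assay and not a number. In this assay compound 2 gives > 10000 nM, likewise a limit. The step that the two limits leave unreadable from compound 1 to compound 2 therefore cannot be read. In this assay compound 3 gives > 10000 nM, again a limit. Compound 3 thus stands only at the boundary of the assay, with no number of its own, and the two other values shown are limits as well. Compound 4 `C[C@H](NC(=O)c1nnn(Cc2ccc(C(F)(F)F)cc2)c1-c1ccccc1)c1ccc(C(=O)O)cc1` is compound 3 with phenyl in place of hydrogen on an aromatic carbon. Among the measured compounds shown here, no measured step bears on this change, since every value so far sits at the limit of > 10000 nM in this assay, at which 3 of the 3 values shown sit. For the measured compounds named here, no size or direction for this change can be anchored on the values so far. The step of an at least 1.1-fold lower number from compound 3 to compound 4 (0.04 log units; that floor lies within the scatter) in this assay is an estimate of my own, and the expectation is that the value stays at the limit. For compound 4 the estimate in this assay is 9000 nM, with a range from 1500 nM to 40000 nM.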

Compound 4, half-maximal inhibitory concentration: > 10000 nM
Compound 4 gave a limit, no number; the forecaster's own chance of this, stated with the estimate: 70%; middle value at least 1.1-fold (0.04 log units) away from the limit.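

No new step can be read between compound 3 and compound 4 in this assay: each gives a limit and not a number. The compounds shown leave open whether any benzyl group or core substituent gives a readable number in this assay, and what size the phenyl change has.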